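This account rests on a few compounds, and the source may have more. Where it says the series, first, only, none or still open, it means among the compounds named here.

Three urea compounds sharing one core have been measured in a physicochemical assay for solubility, at pH 7.4; on this read-out lower numbers stand for lower solubility and higher numbers for higher solubility. Compound 1 `Cc1cc(NC(=O)Nc2ccc(C(C)(C)C)cc2)c2ccccc2n1` carries a tert-butyl group on its outer ring and gives 6200 nM. Compound 2 `CSc1ccc(NC(=O)Nc2cc(C)nc3ccccc23)cc1` differs from compound 1 in a single place: methylsulfanyl in place of tert-butyl on an aromatic carbon. That exchange produced a step of a 4.8-fold lower number from compound 1 to compound 2 (0.68 log units; beyond the scatter). Compound 3 `Cc1cc(NC(=O)Nc2ccccc2C(C)(C)C)c2ccccc2n1` is built from the same atoms as compound 1, joined differently; the difference between the two cores is not broken down here. In this assay compound 3 gives 100 nM, the lowest of the three numbers, while compound 2 gives 1300 nM and stands nearest to it.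

Compound 4 `CSc1ccccc1NC(=O)Nc1cc(C)nc2ccccc12` has not yet been measured. It differs from compound 3 in the following way: methylsulfanyl in place of tert-butyl on an aromatic carbon. Going by the values given here, the change is the same kind of change as the one from compound 1 to compound 2, but not the same: in that earlier pair the place is para to a large group, whereas here it is ortho to a large group.

The expectation for compound 4 rests on the step of a 4.8-fold lower number from compound 1 to compound 2 (0.68 log units; beyond the scatter), applied to the value of compound 3, with wider uncertainty because the surroundings of the place differ. The step expected from compound 3 to compound 4 is a 2.5-fold lower number from compound 3 to compound 4 (0.40 log units; beyond the scatter). Compound 4 is therefore estimated to give 40 nM in this assay, most likely between 10 nM and 160 nM.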

Compound 4, solubility: 21000 nM
Estimate against measurement, compound 4: 530-fold (2.72 log units) below; measured number outside the range, above it.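

In this assay the exchange of tert-butyl for methylsulfanyl gave a 210-fold higher number from compound 3 to compound 4 (2.32 log units; beyond the scatter) while the same exchange on the other core gave a 4.8-fold lower number from compound 1 to compound 2 (0.68 log units; beyond the scatter) and so the two steps, both beyond the usual scatter, point in opposite directions. This shows that in this series the outcome of the change cannot simply be carried from one core to the other, and that a step read in one setting, here with the place ortho to a large group in compound 3 and compound 4, may not even keep its direction in another. It does not show that the change will always raise the number when the place is ortho to a large group, since each direction rests on a single pair, and nothing available here accounts for the reversal.

The compounds shown hold only two groups at this place, tert-butyl and methylsulfanyl, so it remains open whether a third group would follow the step seen in one pair, the step seen in the other, or neither. An amine, a carboxylic acid or a longer chain at the same place, compared on both cores, would show how far the reversal extends.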